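This account rests on a few compounds, and the source may have more. Where it says the series, first, only, none or still open, it means among the compounds named here.

Measured so far:
Compound 1 `O=C(O)c1cnc(-c2ccccc2[N+](=O)[O-])[nH]c1=O`; in a functional assay on the whole organism (strain Sprague-Dawley) for inhibition, with Rattus norvegicus as the target, with a stated time of 10 min (on this read-out lower numbers stand for an effect already at smaller amounts and higher numbers for an effect only at larger amounts of compound), compound 1 gives > 50 mg/kg, which is a limit of the assay and not a number.
Compound 2 `CCOc1ccccc1-c1ncc(C(=O)O)c(=O)[nH]1`; compound 2 gives 0.5 mg/kg.
Compound 3 `CCC(C)Oc1ccccc1-c1ncc(C(=O)O)c(=O)[nH]1`; compound 3 gives 0.5 mg/kg.

Compound 3 sits level with compound 2 at the digits shown, since no change at the digits printed from compound 2 to compound 3 (within the scatter). Compound 4 `CCSc1ccccc1-c1ncc(C(=O)O)c(=O)[nH]1` differs from compound 3 in one place: ethylsulfanyl in place of sec-butoxy on an aromatic carbon. For the measured compounds named here, no measured step swaps an oxygen for a sulfur here. Going by the values given here, the steps that bear on it are an at least 100-fold lower number from compound 1 to compound 2 (2.00 log units; beyond the scatter) and an at least 100-fold lower number from compound 1 to compound 3 (2.00 log units; beyond the scatter), both large, and no change at the digits printed from compound 2 to compound 3 (within the scatter), which shows that a longer chain on the oxygen changed nothing. Compound 4 is therefore expected to remain close to compound 3, with a 1.4-fold higher number from compound 3 to compound 4 (0.15 log units; within the scatter) expected. The estimate for compound 4 in this assay is 0.7 mg/kg, within 0.2 mg/kg to 3 mg/kg.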

Compound 4, dose for 50% inhibition: 25 mg/kg
The estimate for compound 4 lay 36-fold (1.55 log units) below the measured number; the whole stated range lies below it.
By their numbers in this assay, from the lowest: compounds 2 and 3 (each within the scatter of the next); then compound 4. At a limit, above all of these: compound 1.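

In this assay, the atom linking the chain to the aromatic ring proves decisive where changing the chain on oxygen was not: with the ethyl chain kept, sulfur in place of oxygen gives a 50-fold higher number from compound 2 to compound 4 (1.70 log units; beyond the scatter). Ethylsulfanyl in place of sec-butoxy gives the same picture, with a 50-fold higher number from compound 3 to compound 4 (1.70 log units; beyond the scatter). Compound 1 stands at a limit, so an at least 2.0-fold lower number from compound 1 to compound 4 (0.30 log units; that floor lies within the scatter) is only a floor: the limit of > 50 mg/kg in this assay, at which 1 of the 4 values shown sits.

Still open, going by these compounds, is whether a longer chain on the sulfur, or an amine at this place, would bring the number back towards that of compound 2. The compounds shown also cannot say why sulfur costs so much here.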